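A few compounds are considered here, and "the series" means these few. Any claim that something is new, unique, unknown or untested is made for them only; others in the source may bear on it.

Compound 1 `C[C@@H](O)[C@H]1C(=O)N2C(C(=O)OCOC(=O)C(C)(C)C)=C(S[C@@H]3CN[C@H](C(=O)Nc4cccc(C(=O)O)c4)C3)[C@H](C)[C@H]12` and compound 2 `CCOC(=O)C1=C(S[C@@H]2CN[C@H](C(=O)Nc3cccc(C(=O)O)c3)C2)[C@H](C)[C@@H]2[C@@H]([C@@H](C)O)C(=O)N12` share one core and differ only in the ester. In an ADME assay for metabolic stability, read by LC-MS, with a stated time of 3 h, at pH 6.5, tested at 50 uM (a lower number here means that less of the compound is left, a higher number that more of the compound is left), compound 1 gives > 95%, which is a limit of the assay and not a number. In this assay compound 2 likewise gives > 95%, again a limit rather than a number. The step that the two limits leave unreadable from compound 1 to compound 2 therefore cannot be read, since (the limit of > 95% in this assay, at which 2 of the 2 values shown sit). On the numbers shown, compound 2 stands at that limit, together with compound 1. Compound 3 `C[C@@H](O)[C@H]1C(=O)N2C(C(=O)OCC(F)(F)F)=C(S[C@@H]3CN[C@H](C(=O)Nc4cccc(C(=O)O)c4)C3)[C@H](C)[C@H]12` differs from compound 2 by trifluoromethyl in place of methyl on a saturated chain carbon bound to an oxygen next to a carbonyl group. Among the compounds with values here, no measured step bears directly on this change, and the only step known, a step that the two limits leave unreadable from compound 1 to compound 2, is unreadable. The step from compound 2 to compound 3 in this assay is expected to be small, a number at least 5 percentage points lower from compound 2 to compound 3 (that floor lies within the scatter), with no direction beyond the scatter. Compound 3 is therefore estimated at 90% in this assay, between 70% and 98%, with a fair chance that again only the limit is reported.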

Compound 3, percent of the compound remaining: > 95%
Compound 3 ended at the assay's limit; the forecaster's own chance of this, stated with the estimate: 55%; at least 5 percentage points between middle value and limit.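

No new step can be read among compound 1, compound 2 and compound 3 in this assay, where each value is a limit of the assay and not a number: the limit of > 95% in this assay, at which 3 of the 3 values shown sit. The compounds shown leave open whether their esters differ at all in this assay.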